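This account rests on a few compounds, and the source may have more. Where it says the series, first, only, none or still open, it means among the compounds named here.

In an ADME assay on MT4 cells (Homo sapiens) for cytotoxicity, read by MTT assay, with a stated time of 5 days (a lower number here means that less compound is tolerated, a higher number that more compound is tolerated), compound 1 `Cc1cc(C)cc(S(=O)(=O)c2c(C(=O)N[C@H]3CCN(Cc4cccnc4)C3)[nH]c3ccc(Cl)cc23)c1` gives 22800 nM, and compound 2 `Cc1cc(C)cc(S(=O)(=O)c2c(C(=O)N[C@H]3CCN(Cc4n[nH]c(=O)n4C)C3)[nH]c3ccc(Cl)cc23)c1` gives 21500 nM, so the two sit within the scatter of each other. Compound 3 `Cc1cc(C)cc(S(=O)(=O)c2c(C(=O)N[C@H]3CCN(Cc4ccccc4C#N)C3)[nH]c3ccc(Cl)cc23)c1` is reported only as a limit, > 228000 nM. Compound 4 `Cc1cc(C)cc(S(=O)(=O)c2c(C(=O)NC3CN(CC(N)=O)C3)[nH]c3ccc(Cl)cc23)c1` departs from compound 1 on an amide-type nitrogen: 1-(carbamoylmethyl)azetidin-3-yl in place of 1-((pyridin-3-yl)methyl)pyrrolidin-3-yl on an amide-type nitrogen. The measured steps changed only the group on a saturated chain carbon bound to an amine nitrogen in a ring, so they are a loose guide here. Of these, a 1.1-fold lower number from compound 1 to compound 2 (0.03 log units; within the scatter) stays within the scatter, while an at least 10-fold higher number from compound 1 to compound 3 (1.00 log units; beyond the scatter) lies beyond it. On that uneven evidence, a moderate rise in the number is expected, a 2.6-fold higher number from compound 1 to compound 4 (0.42 log units; beyond the scatter). Compound 4 is estimated at 60000 nM, with an expected range of 18000 nM to 228000 nM.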

Compound 4, half-maximal cytotoxic concentration: 25500 nM
Compound 4: middle estimate off by 2.4-fold (0.37 log units), on the high side; low and high end bracket the measured number.
By their numbers in this assay, from the lowest: compounds 2, 1 and 4 (each within the scatter of the next). At a limit, above all of these: compound 3.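

In this assay, putting 1-(carbamoylmethyl)azetidin-3-yl in place of 1-((pyridin-3-yl)methyl)pyrrolidin-3-yl on an amide-type nitrogen gives a 1.1-fold higher number from compound 1 to compound 4 (0.05 log units; within the scatter). Unlike the earlier steps, this one replaces the whole amine-bearing ring and removes the aromatic ring, yet compound 4 stays within the scatter of compound 1. Compound 3 remains the only compound reported at a limit: the limit of > 228000 nM in this assay, at which 1 of the 4 values shown sits.

Ring size and the attached group changed together in compound 4, so their contributions cannot be separated. Going by these compounds, it remains open whether a carboxylic acid in place of the carbamoyl group would stay within that scatter.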